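Trading a trifluoromethylphenyl for a fluoro-methoxyphenyl arm

The source may hold more compounds than are shown below. What is called first, only, known or untested is meant among the compounds shown, and "the series" means these compounds.

Compound 2 `COc1ccc(C(=O)c2cc(OC)c(OC)c(OC)c2)cc1NC(=O)/C=C/c1ccc(C(F)(F)F)cc1` gives 4300 nM in a functional assay on DU-145 cells (Homo sapiens) for cytotoxicity, read by MTT assay, with a stated time of 72 h (on this read-out higher numbers stand for weaker inhibition and lower numbers for stronger inhibition), the lower of the two numbers, while compound 1 `C#CCOc1cccc(/C=C/C(=O)Nc2cc(C(=O)c3cc(OC)c(OC)c(OC)c3)ccc2OC)c1` gives 15800 nM. Compound 3 `COc1cc(/C=C/C(=O)Nc2cc(C(=O)c3cc(OC)c(OC)c(OC)c3)ccc2OC)ccc1F` carries 4-fluoro-3-methoxyphenyl in place of 4-(trifluoromethyl)phenyl on a double-bonded chain carbon bound to a double-bonded chain carbon. Among the measured compounds shown here, the only measured step on this chain carbon, a 3.7-fold lower number from compound 1 to compound 2 (0.57 log units; beyond the scatter), shows that the aryl group here can shift this assay by a modest step, and compound 3 brings back a methoxy acceptor resembling the weaker compound 1. A modest step of a 1.4-fold higher number from compound 2 to compound 3 (0.14 log units; within the scatter) toward weaker inhibition is therefore expected. Compound 3 is estimated at 6000 nM, within a range from 1800 nM to 20000 nM.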

Compound 3, half-maximal inhibitory concentration: 12100 nM
Beside the measured number, compound 3's estimate is 2.0-fold (0.30 log units) below it, within the range that was stated.
By their numbers in this assay, from the lowest: compound 2; then compounds 3 and 1 (each within the scatter of the next).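

On this chain carbon, the 4-fluoro-3-methoxyphenyl arm does not keep the lower number seen with the 4-(trifluoromethyl)phenyl arm in this assay, with a 2.8-fold higher number from compound 2 to compound 3 (0.45 log units; beyond the scatter). Set against the 3-(propargyloxy)phenyl arm, it shows a 1.3-fold lower number from compound 1 to compound 3 (0.12 log units; within the scatter), so compound 1 and compound 3 read alike although their arms differ, and compound 2 alone stands apart. No evidence is available that bears on this result. Going by these compounds, what remains open is whether a 4-chlorophenyl, a 4-nitrilephenyl or an arm bearing an amine would match or pass compound 2.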